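Adding fluoro to compound 1: what to expect

The compounds below may be only part of what the source reports. "The series", "measured", "known", "first", "only" and "open" are said of these compounds alone.

In a physicochemical assay for pharmacokinetics, at pH 6 (on this read-out higher numbers stand for a longer-lived compound and lower numbers for a shorter-lived compound), the measured compounds are these:
Compound 1 `O=C(Sc1cccnc1C(=O)O)c1ccccc1` gives 21.1 h
Compound 2 `O=C(Sc1cccnc1C(=O)O)c1cccc(Cl)c1` gives 4.7 h
Compound 3 `O=C(Sc1cccnc1C(=O)O)c1ccccc1Cl` gives 27.2 h

Compound 1 stands at the upper end of these numbers alongside compound 3, with a 1.3-fold higher number from compound 1 to compound 3 (0.11 log units; within the scatter). Compound 2 stands clearly apart, with a 4.5-fold lower number from compound 1 to compound 2 (0.65 log units; beyond the scatter).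

The next compound is compound 4 `O=C(Sc1cccnc1C(=O)O)c1ccc(F)cc1`, which has not yet been measured in this assay. It differs from compound 1 by one change: fluoro in place of hydrogen on an aromatic carbon. Fluoro replaces hydrogen on an aromatic carbon, para to a large group.

Among the measured compounds shown here, two measured steps bear on this change, although both introduce chloro rather than fluoro, and no measured compound carries fluoro. They do not agree. One is modest, a 4.5-fold lower number from compound 1 to compound 2 (0.65 log units; beyond the scatter), while the other stays within the scatter, a 1.3-fold higher number from compound 1 to compound 3 (0.11 log units; within the scatter). The evidence therefore points to a small step at most, leaning slightly downward on the strength of a 4.5-fold lower number from compound 1 to compound 2 (0.65 log units; beyond the scatter), and most likely not beyond the scatter. The expected step is a 1.4-fold lower number from compound 1 to compound 4 (0.15 log units; within the scatter). For compound 4 the estimated half-life is 15 h, with an expected range from 7 h to 28 h.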

Compound 4, half-life: 12.1 h
Compound 4: middle estimate off by 1.2-fold (0.09 log units), on the high side, and the stated range covers the measured number.
By their numbers in this assay, from the lowest: compound 2; then compounds 4, 1 and 3 (each within the scatter of the next, the first and the last beyond it).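

In this assay, among the compounds shown here, the fluoro of compound 4, on an aromatic carbon para to a large group, gives the first reading at this place on the ring, and the step, a 1.7-fold lower number from compound 1 to compound 4 (0.24 log units; within the scatter), cannot be told apart from the scatter. For the compounds shown here, this adds a third place to the two chloro steps, of which one stays within the scatter, a 1.3-fold higher number from compound 1 to compound 3 (0.11 log units; within the scatter), and one goes beyond it, a 4.5-fold lower number from compound 1 to compound 2 (0.65 log units; beyond the scatter), so a halogen on this aromatic ring does not shift the half-life beyond the scatter in every case, with compound 2 the one compound that goes against a flat picture. No measured information accompanies the result to explain the step, and none bears on how the fluoro acts here.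

The compounds shown leave open whether chloro on this same carbon would stay as close to compound 1 as fluoro does, and whether a bulkier group such as methoxy or an amine would do so as well. They also leave open whether fluoro placed where the chloro sits in compound 2 would repeat the step seen there.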